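Naphthyl-trimethoxyphenyl series: ester to acid

The compounds below may be only part of what the source reports. "The series", "measured", "known", "first", "only" and "open" are said of these compounds alone.

Measured so far:
compound 1 `CCOC(=O)CCO/N=C(/c1ccc(OC)c(OC)c1OC)c1cccc2ccccc12`, a functional assay on MCF7 cells (Homo sapiens) for inhibition, read by sulforhodamine B assay, with a stated time of 48 h; a higher number here means a weaker inhibitor, a lower number a stronger inhibitor > 20000 nM
compound 2 `C=C(c1ccc(OC)c(OC)c1OC)c1cccc2ccccc12`, this assay 11700 nM
compound 3 `COc1ccc(/C(=C/c2ccc(C)cc2)c2cccc3ccccc23)c(OC)c1OC`, this assay > 20000 nM

In this assay compound 1 gives only a limit of the assay, not a number. Compound 3 likewise gives only a limit in this assay. Among the measured compounds shown here, compound 2 gives a number, the one value here that does; no step between compound 2 and any other compound is given, so only the two values can be set side by side. Compound 1 thus stands at the limit, where two of the three values sit (the limit of > 20000 nM in this assay, at which 2 of the 3 values shown sit).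

Compound 4 `COc1ccc(/C(=N/OCC(=O)O)c2cccc3ccccc23)c(OC)c1OC` differs from compound 1 in one place (carboxy in place of (ethoxycarbonyl)methyl on a saturated chain carbon bound to an oxygen on an unsaturated carbon). For the measured compounds named here, no measured step connects compound 1 to any other compound, so no guide to the size of this change exists. In this assay the step that the limit leaves unreadable from compound 1 to compound 4 is expected to be none beyond the scatter, with compound 4 most likely again returning a limit. The estimate for compound 4 is 25000 nM, within 8000 nM to 80000 nM.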

Compound 4, half-maximal inhibitory concentration: > 20000 nM
Compound 4 ended at the assay's limit; the forecaster's own chance of this, stated with the estimate: 70%; the middle value is on the limit's open side.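

Compound 1 and compound 4 both return only a limit in this assay, so no step between them can be read: the limit of > 20000 nM in this assay, at which 3 of the 4 values shown sit.

The compounds shown leave open whether carboxy in place of (ethoxycarbonyl)methyl changes inhibition at all, since neither compound of this pair has a numerical value.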